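Swapping Bromine for Iodine on an Unchanged Cytotoxicity Limit

The source may report more compounds than this note shows. Statements on the series, on what has been measured and on what is new or still open speak of the compounds shown alone.

Compound 1 `COc1ccc(/C=C2\CC[C@H]3C(C)(C)CCC[C@]3(C)[C@H]2CCC(C)CC(=O)O)cc1`, compound 2 `CC(CC[C@H]1/C(=C/c2ccc([N+](=O)[O-])cc2)CC[C@H]2C(C)(C)CCC[C@]12C)CC(=O)O` and compound 3 `CC(CC[C@H]1/C(=C/c2ccc(Br)cc2)CC[C@H]2C(C)(C)CCC[C@]12C)CC(=O)O` share one core and differ only in a single group on the aromatic ring. In an ADME assay on HUVEC cells (Homo sapiens) for cytotoxicity, read by MTT assay, with a stated time of 24 h (a higher number here means a weaker inhibitor, a lower number a stronger inhibitor), compound 1 gives > 200000 nM, which is a limit of the assay rather than a number. Compound 2 likewise gives > 200000 nM, again a limit. Compound 3 gives > 200000 nM, also a limit. All three values sit at the limit of > 200000 nM in this assay, at which 3 of the 3 values shown sit, so the steps a step that the two limits leave unreadable from compound 1 to compound 2, a step that the two limits leave unreadable from compound 1 to compound 3 and a step that the two limits leave unreadable from compound 2 to compound 3 cannot be sized. Compound 4 `CC(CC[C@H]1/C(=C/c2ccc(I)cc2)CC[C@H]2C(C)(C)CCC[C@]12C)CC(=O)O` differs from compound 3 by iodo in place of bromo on an aromatic carbon. For the measured compounds named here, none of the measured steps shows a readable change, so compound 4 is expected to give 300000 nM, within 150000 nM to 1000000 nM, most probably reported as a limit again. The step that the limit leaves unreadable from compound 3 to compound 4 is therefore expected to be none beyond the scatter.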

Compound 4, half-maximal inhibitory concentration: 194000 nM
The estimate for compound 4 lay 1.5-fold (0.19 log units) above the measured number; the range from low to high includes it.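

In this assay compound 4 is the first of these compounds to give a number rather than a limit, so iodo on this aromatic carbon allows a floor to be put on the step: an at least 1.0-fold lower number from compound 3 to compound 4 (0.01 log units; that floor lies within the scatter). The floors against nitro and methoxy are similar: an at least 1.0-fold lower number from compound 2 to compound 4 (0.01 log units; that floor lies within the scatter) and an at least 1.0-fold lower number from compound 1 to compound 4 (0.01 log units; that floor lies within the scatter). The other values remain limits: the limit of > 200000 nM in this assay, at which 3 of the 4 values shown sit.

For the compounds shown here, only one end of each step is a number, so their true sizes stay open. Also open, from the compounds shown here alone, is whether an amine or a longer chain on this aromatic carbon would give a clearly lower number than compound 4.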